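The source may report more compounds than this note shows. Statements on the series, on what has been measured and on what is new or still open speak of the compounds shown alone.

Compound 1 `Cc1oc2c([C@H]3CCN(C)C[C@H]3O)c(O)cc(O)c2c(=O)c1C(O)c1ccc(Cl)cc1`, compound 2 `Cc1oc2c([C@H]3CCN(C)C[C@H]3O)c(O)cc(O)c2c(=O)c1C(O)c1ccc(F)cc1` and compound 3 `CN1CC[C@H](c2c(O)cc(O)c3c(=O)cc(/C=C/c4ccccc4F)oc23)[C@H](O)C1` were all tested in a functional assay on Caco-2 cells (Homo sapiens) for inhibition, read by MTT assay, with a stated time of 48 h, tested at 10 uM; on this read-out lower numbers stand for less inhibition of growth and higher numbers for more inhibition of growth at the one concentration tested. Compound 1 gives 3%, compound 2 gives 11% and compound 3 gives 68%. Compound 1 and compound 2 differ by chloro in place of fluoro on an aromatic carbon, a change that produced a number 8 percentage points lower from compound 2 to compound 1 (within the scatter). How the core of compound 3 differs from the core of compound 2 is not broken down here. Compound 4 `CN1CC[C@H](c2c(O)cc(O)c3c(=O)cc(/C=C/c4ccccc4Cl)oc23)[C@H](O)C1` has not yet been measured; it differs from compound 3 by chloro in place of fluoro on an aromatic carbon. This is the same kind of change as that between compound 2 and compound 1, but the place differs: para to a large group in the earlier pair, ortho to a large group here. Compound 4 is expected to give 62%, within 45% to 78%, because the same kind of exchange gave a number 8 percentage points lower from compound 2 to compound 1 (within the scatter). The step this estimate implies, a number 6 percentage points lower from compound 3 to compound 4 (within the scatter), is expected to remain within the usual scatter.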

Compound 4, percent growth inhibition at one concentration: 65%
Beside the measured number, compound 4's estimate is 3 percentage points below it, within the range that was stated.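

In this assay, chloro in place of fluoro on an aromatic carbon gave a number 3 percentage points lower from compound 3 to compound 4 (within the scatter). Set beside the earlier pair, the same exchange reads alike on two cores: the same change on two cores in this assay, a number 8 percentage points lower (within the scatter) from compound 2 to compound 1 and a number 3 percentage points lower (within the scatter) from compound 3 to compound 4, 5 percentage points apart, within the scatter of two such steps

This shows that, on both of these cores, the exchange produced no change that can be told from the scatter, but it does not show that fluoro and chloro would be interchangeable on other cores or at other concentrations.

The compounds shown leave open whether a larger replacement, such as bromo, methoxy or a nitrile, would also leave growth inhibition unchanged on the 2-chlorophenyl ring. They also leave open what an amine or a carboxylic acid would do in that place.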